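Replacing 3-chlorophenyl with naphthalen-2-yl: what to expect

A few compounds are considered here, and "the series" means these few. Any claim that something is new, unique, unknown or untested is made for them only; others in the source may bear on it.

Of the compounds shown here, three sharing one core have been tested in a functional assay on MDA-MB-231 cells (Homo sapiens) for antiproliferative activity, read by MTT assay, with a stated time of 24 h; on this read-out lower numbers stand for stronger inhibition and higher numbers for weaker inhibition. There, compound 1 (`O=C(c1cc(Cl)ccn1)N1CCN(c2nccc(Oc3cc(Cl)cc(Cl)c3)n2)CC1`) gives 16700 nM as its value, and compound 3 (`O=C(Nc1cccc(Cl)c1)N1CCN(c2nccc(Oc3cc(Cl)cc(Cl)c3)n2)CC1`) gives the lowest number (7900 nM). Compound 2 (`O=C1CC[C@@H](C(=O)N2CCN(c3nccc(Oc4cc(Cl)cc(Cl)c4)n3)CC2)N1`) reads > 50000 nM as a limit of the assay, not a number. Compound 3 is thus the most potent of the three.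

Compound 4 (`O=C(Nc1ccc2ccccc2c1)N1CCN(c2nccc(Oc3cc(Cl)cc(Cl)c3)n2)CC1`) carries naphthalen-2-yl in place of 3-chlorophenyl on an amide-type nitrogen. For the measured compounds named here, no measured step makes this exact change. Changing the group on the carbonyl carbon gave a 2.1-fold lower number from compound 1 to compound 3 (0.33 log units; beyond the scatter) and an at least 6.3-fold lower number from compound 2 to compound 3 (0.80 log units; beyond the scatter) against a limit. The larger step involves 5-oxopyrrolidin-2-yl, a group absent from compound 4. The smaller one is the closer guide, so only a small shift in this assay is expected, probably within the scatter and with no firm direction. The expected change is small (a 1.1-fold lower number from compound 3 to compound 4 (0.05 log units; within the scatter)). The estimated value for compound 4 is 7000 nM (range 2500 nM to 20000 nM).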

Compound 4, half-maximal inhibitory concentration: 46800 nM
Beside the measured number, compound 4's estimate is 6.7-fold (0.83 log units) below it; the measured number lies above the stated range.
By their numbers in this assay, from the lowest: compound 3; then compound 1; then compound 4. At a limit, above all of these: compound 2.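

In this assay, for the compounds shown here, the group on the amide-type nitrogen matters, and the earlier compounds did not test this position: naphthalen-2-yl in place of 3-chlorophenyl gives a 5.9-fold higher number from compound 3 to compound 4 (0.77 log units; beyond the scatter). An amino group on the carbonyl carbon does not bring a lower number by itself, since (naphthalen-2-yl)amino gives a 2.8-fold higher number from compound 1 to compound 4 (0.45 log units; beyond the scatter), the opposite direction to (3-chlorophenyl)amino. Compound 2 stands at a limit of the assay, not a number: the limit of > 50000 nM in this assay, at which 1 of the 4 values shown sits. Set against that limit, (naphthalen-2-yl)amino gives an at least 1.0-fold lower number from compound 2 to compound 4 (0.02 log units; that floor lies within the scatter), and this is only a floor for the step.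

This change adds a second aromatic ring and removes the chlorine together, so the compounds shown do not separate these two differences. A plain phenyl or a 4-chlorophenyl group on the same nitrogen would help to tell them apart.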